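Adding a second pentylcarbonyl group to compound 2

The compounds below may be only part of what the source reports. "The series", "measured", "known", "first", "only" and "open" are said of these compounds alone.

For the measured compounds named here, in a functional assay on A549 cells (Homo sapiens) for antiproliferative activity, read by MTT assay, with a stated time of 72 h (a lower number here means a stronger inhibitor, a higher number a weaker inhibitor), compound 2 (`CCCCCC(=O)Oc1cc(C(=O)C2=C3OC(C)(C)[C@@H](CC=C(C)C)C[C@@]34C[C@@H](CC=C(C)C)C(C)(C)[C@H]3CCC(C)(C)O[C@]34OC2=O)ccc1O`) gives 19500 nM as the only true number so far. Compound 1 (`CCCCCCCC(=O)Oc1cc(C(=O)C2=C3OC(C)(C)[C@@H](CC=C(C)C)C[C@@]34C[C@@H](CC=C(C)C)C(C)(C)[C@H]3CCC(C)(C)O[C@]34OC2=O)ccc1O`) gives > 20000 nM and this is a limit of the assay, not a number.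

Compound 3 (`CCCCCC(=O)Oc1ccc(C(=O)C2=C3OC(C)(C)[C@@H](CC=C(C)C)C[C@@]34C[C@@H](CC=C(C)C)C(C)(C)[C@H]3CCC(C)(C)O[C@]34OC2=O)cc1OC(=O)CCCCC`) differs from compound 2 in one place. The change is pentylcarbonyl in place of hydrogen on an oxygen on an aromatic ring in short: pentylcarbonyl in place of hydrogen on an oxygen on an aromatic ring, which turns a hydroxy into (pentylcarbonyl)oxy.

Going by the values given here, the one measured step (an at least 1.0-fold lower number from compound 1 to compound 2 (0.01 log units; that floor lies within the scatter)) shortens a saturated chain and leaves this oxygen untouched, so it is only a loose guide. It shows that changing the length of that chain gave no measurable shift here. No step beyond the scatter is therefore expected in this assay and no firm direction can be given. Compound 3 may also return a limit (the limit of > 20000 nM in this assay, at which 1 of the 2 values shown sits) rather than a number.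

The expected step is a 1.1-fold higher number from compound 2 to compound 3 (0.05 log units; within the scatter) as an estimate. For compound 3 the estimated value is 22000 nM with an expected range from 10000 nM to 45000 nM at this stage.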

Compound 3, half-maximal inhibitory concentration: 19200 nM
For compound 3 the middle estimate is 1.1-fold (0.06 log units) above the measured one, and the stated range covers the measured number.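

In this assay, replacing the hydrogen on this oxygen on an aromatic ring with pentylcarbonyl, which turns a hydroxy into (pentylcarbonyl)oxy, gives a 1.0-fold lower number from compound 2 to compound 3 (0.01 log units; within the scatter). The earlier step changed only the length of a saturated chain, whereas this one alters the oxygen itself, and it shows that compound 2 and compound 3 cannot be told apart in this assay even though a hydroxy has been replaced by a group of several heavy atoms. Compound 1 remains the only one of the three at a limit of the assay rather than a number: the limit of > 20000 nM in this assay, at which 1 of the 3 values shown sits.

This single change at one oxygen cannot show whether a different group there, such as a small acetyl, a longer chain or an amine in place of the hydroxy, would move the number beyond the usual scatter. Also open, as far as these compounds go, is what the shared core would give with a hydroxy in place of the (pentylcarbonyl)oxy group that compound 2 carries, a change that would show whether that remaining group matters in this assay.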